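Methoxy in place of hydrogen on compound 2

A few compounds are considered here, and "the series" means these few. Any claim that something is new, unique, unknown or untested is made for them only; others in the source may bear on it.

Measured so far in an ADME assay on L02 cells (Homo sapiens) for cytotoxicity, read by MTT assay, with a stated time of 24 h; a lower number here means a stronger inhibitor, a higher number a weaker inhibitor:
- compound 1 `COc1cc(/C=C2\CN(C)C/C(=C\c3ccccc3F)C2=O)cc(OC)c1` 11900 nM
- compound 2 `COc1cc(/C=C2\CN(C)C/C(=C\c3ccc(C#N)cc3)C2=O)cc(OC)c1` 14000 nM

Compound 2 stands level with compound 1, as the step of a 1.2-fold higher number from compound 1 to compound 2 (0.07 log units; within the scatter) shows. Among the measured compounds shown here, that step exchanged a different aromatic group, so it says little about compound 3 `COc1cc(/C=C2\CN(C)C/C(=C\c3ccc(C#N)cc3)C2=O)cc(OC)c1OC`, which differs from compound 2 by methoxy in place of hydrogen on an aromatic carbon at a place no measured step has touched. Without such evidence, no step beyond the scatter is expected in this assay, and no direction is favoured. Compound 3 is expected near 11000 nM as an estimate, with a range from 4500 nM to 24000 nM around it. The estimated change is a 1.3-fold lower number from compound 2 to compound 3 (0.10 log units; within the scatter) and remains tentative.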

Compound 3, half-maximal inhibitory concentration: 18600 nM
Estimate against measurement, compound 3: 1.7-fold (0.23 log units) below; measured number inside the range.
By their numbers in this assay, from the lowest: compounds 1, 2 and 3 (each within the scatter of the next).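

In this assay, methoxy in place of hydrogen on an aromatic carbon gives a 1.3-fold higher number from compound 2 to compound 3 (0.12 log units; within the scatter) at this place. This position, ortho to two methoxy groups and para to a large group, therefore accepts the added methoxy without a step beyond the scatter, which the earlier pair, differing only in another aromatic group, could not show. No measured evidence bears on this result. From the compounds shown here alone, whether an amine, a carboxylic acid or a longer chain such as butoxy at this position would also stay within the scatter remains open. Also open, going by these compounds, is whether methoxy here gives a similar step alongside the 2-fluorophenyl group of compound 1.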